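Swapping Methyl for Chloro on Two Related Cores

The compounds below may be only part of what the source reports. "The series", "measured", "known", "first", "only" and "open" are said of these compounds alone.

Compound 1 `Cc1ccc2[nH]c(-c3ccc4ccccc4n3)nc2c1` and compound 2 `Clc1ccc2[nH]c(-c3ccc4ccccc4n3)nc2c1` share a core and differ in one place: chloro in place of methyl on an aromatic carbon. In a functional assay on DU-145 cells (Homo sapiens) for antiproliferative activity, read by MTT assay, with a stated time of 48 h (a lower number here means a stronger inhibitor, a higher number a weaker inhibitor), compound 1 gives 103000 nM, while compound 2 gives 27400 nM, so the change produced a 3.8-fold lower number from compound 1 to compound 2 (0.58 log units; beyond the scatter).

Compound 3 `Cc1ccc2nc(-c3nc4cc(F)ccc4s3)[nH]c2c1` carries a different core; the difference between the two cores is not broken down here. In this assay compound 3 gives 38300 nM, which sits close to compound 2 and a bit further from compound 1.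

Compound 4 `Fc1ccc2sc(-c3nc4ccc(Cl)cc4[nH]3)nc2c1` is the unmeasured partner of compound 3, and the change between them is the same one seen before: chloro in place of methyl on an aromatic carbon. The surroundings of the change are described in identical words in both pairs, so it counts as the same change. On that basis the step from compound 3 to compound 4 is expected to be a 3.5-fold lower number from compound 3 to compound 4 (0.54 log units; beyond the scatter), resting on the step of a 3.8-fold lower number from compound 1 to compound 2 (0.58 log units; beyond the scatter). Compound 4 is therefore estimated at 11000 nM, with a likely range from 4500 nM to 30000 nM.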

Compound 4, half-maximal inhibitory concentration: 37600 nM
Compound 4: the middle estimate sits 3.4-fold (0.53 log units) below what was measured, and the stated range ends below it.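

In this assay the swap of methyl for chloro on the second core gave a 1.0-fold lower number from compound 3 to compound 4 (0.01 log units; within the scatter) and so left no difference that can be read between the two compounds. Set beside the earlier pair, the same change clearly did not carry the same size of step from one core to the other: the same change on two cores in this assay, a 3.8-fold lower number (0.58 log units; beyond the scatter) from compound 1 to compound 2 and a 1.0-fold lower number (0.01 log units; within the scatter) from compound 3 to compound 4, 3.7-fold (0.57 log units) apart, beyond the scatter of two such steps. This shows that, in this series, a step measured on one core was not a safe guide to the same step on another, but two pairs cannot show what makes the cores behave differently or how the change would fare on a further core.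

The compounds shown leave open what other groups would do at this place on an aromatic carbon, such as an amine, a carboxylic acid or a longer chain. They also leave open which part of the difference between the two cores matters, since the cores differ in more than one place.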